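From compound 2 to compound 4: one group exchanged

The compounds below may be only part of what the source reports. "The series", "measured", "known", "first", "only" and "open" are said of these compounds alone.

Of the compounds shown here, three have been measured in a functional assay on HCT-15 cells (Homo sapiens) for cytotoxicity, read by ELISA, with a stated time of 4 days (a higher number here means a weaker inhibitor, a lower number a stronger inhibitor), so far.
Compound 1 `Clc1ccc(-c2cc(-c3ccoc3)cc(-c3ccco3)n2)s1` gives 1280 nM here.
Compound 2 `Cc1ccsc1-c1cc(-c2ccc(Cl)o2)cc(-c2ccco2)n1` gives 26300 nM here.
Compound 3 `Cc1ccsc1-c1cc(-c2ccc(Cl)o2)cc(-c2cccnc2)n1` gives > 50000 nM as a limit of the assay.

Only two of these results are numbers, and compound 2 holds the higher of them. Compound 1 is its nearest neighbour, lower by a margin beyond the scatter. The result for compound 3 is a limit and not a number.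

Compound 4 `Clc1ccc(-c2cc(-c3ccco3)nc(-c3ccc(Cl)s3)c2)o1` departs from compound 2 in one place, with 5-chlorothiophen-2-yl in place of 3-methylthiophen-2-yl on an aromatic carbon, next to the ring nitrogen 5-chlorothiophen-2-yl in place of 3-methylthiophen-2-yl on an aromatic carbon here.

Going by the values given here, the only measured step is an at least 1.9-fold higher number from compound 2 to compound 3 (0.27 log units; that floor lies within the scatter) with pyridin-3-yl in place of furan-2-yl. It concerns a different group and gives no guide to the size of this change. The better guide is compound 1, which carries the entering 5-chlorothiophen-2-yl and gives 1280 nM in this assay as a single example. On that ground a lower number, beyond the scatter, is expected.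

The expected size of the change is an 11-fold lower number from compound 2 to compound 4 (1.02 log units; beyond the scatter) in that direction. For compound 4 the estimated value is 2500 nM with an expected range from 500 nM to 12000 nM here.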

Compound 4, half-maximal inhibitory concentration: > 50000 nM
Compound 4: only a limit was reported; the forecaster's own chance of this, stated with the estimate: 7%; middle value at least 20-fold (1.30 log units) from the limit.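

In this assay compound 4 gives > 50000 nM, and this is a limit of the assay and not a number. The 5-chlorothiophen-2-yl group next to the ring nitrogen therefore does not by itself go with a low number, since compound 1 carries the same group and the step to compound 4, with 5-chlorofuran-2-yl in place of furan-3-yl, is an at least 39-fold higher number from compound 1 to compound 4 (1.59 log units; beyond the scatter), so at this pair the group at the other place counts for a great deal. The exchange of 3-methylthiophen-2-yl for 5-chlorothiophen-2-yl gives an at least 1.9-fold higher number from compound 2 to compound 4 (0.27 log units; that floor lies within the scatter), which shows no gain from the entering group, though its true size stays unknown, as the result stops at the top of the range read here: the limit of > 50000 nM in this assay, at which 2 of the 4 values shown sit.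

The compounds shown leave open how far compound 4 lies past that limit, and whether 5-chlorothiophen-2-yl would keep a low number with a group other than furan-3-yl at the second place. They also leave open what an amine such as morpholine, set on this same aromatic carbon next to the ring nitrogen, would give in this assay.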